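This account rests on a few compounds, and the source may have more. Where it says the series, first, only, none or still open, it means among the compounds named here.

Measured in a functional assay on DU-145 cells (Homo sapiens) for inhibition, read by trypan blue exclusion, with a stated time of 96 h; a higher number here means a weaker inhibitor of growth, a lower number a stronger inhibitor of growth:
- compound 1 `O=C(O)c1ccc(C(=O)/C(=C\c2ccc(Cl)c([N+](=O)[O-])c2)SCc2ccccc2F)cc1`: 1000 nM
- compound 2 `O=C(O)c1ccc(C(=O)/C(=C\c2ccc(Br)c([N+](=O)[O-])c2)SCc2ccc(Cl)cc2Cl)cc1`: 1000 nM

Compound 2, at 1000 nM, stands level with compound 1 within the scatter. For the measured compounds named here, the two compounds differ in more than one place, and no measured pair isolates a single change.

Compound 3 `O=C(O)c1ccc(C(=O)/C(=C\c2ccc(Cl)c([N+](=O)[O-])c2)SCc2ccc(Cl)cc2Cl)cc1` is not yet measured. It departs from compound 2 by chloro in place of bromo on an aromatic carbon, with chloro in place of bromo on an aromatic carbon.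

In this assay, no step beyond the scatter is expected in either direction, and the expected step is no change at the digits printed from compound 2 to compound 3 (within the scatter). This expectation rests on compound 2 at 1000 nM. The estimate for compound 3 is 1000 nM, with an expected range of 400 nM to 2500 nM.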

Compound 3, concentration for 50% growth inhibition: 1000 nM
Compound 3: the middle estimate sits on the measured number at the digits printed; low and high end bracket the measured number.
By their numbers in this assay, from the lowest: compounds 1, 2 and 3 (each within the scatter of the next).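

In this assay, for the compounds shown here, chloro in place of bromo on the aromatic carbon ortho to the nitro group gives no change at the digits printed from compound 2 to compound 3 (within the scatter), the first single-change reading at this position. On the saturated chain carbon bound to a sulfur, 2,4-dichlorophenyl in place of 2-fluorophenyl gives no change at the digits printed from compound 1 to compound 3 (within the scatter), so the two differences carried together by compounds 1 and 2 are now read apart. No measurement on hand bears on the reason for these readings. Still open, as far as these compounds go, is whether a methoxy group at the halogen position, or an amine in place of the nitro group, would move growth inhibition beyond the scatter.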